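The source may hold more compounds than are shown below. What is called first, only, known or untested is meant among the compounds shown, and "the series" means these compounds.

Compound 1 `CC(C)(C)OC(=O)N1CCC(O[C@H]2CC[C@H](Oc3cnc(S(C)(=O)=O)cn3)CC2)CC1` gives 5.9 nM in a functional assay on isolated protein for agonist activity at Glucose-dependent insulinotropic receptor (Homo sapiens), read by HTRF and cAMP accumulation (on this read-out lower numbers stand for an effect already at smaller amounts and higher numbers for an effect only at larger amounts of compound), the lowest of the two numbers measured; compound 2 `CC(C)S(=O)(=O)c1cnc(O[C@H]2CC[C@H](OC3CCN(C(=O)OC(C)(C)C)CC3)CC2)cn1` gives 18.5 nM in this assay, and the change from compound 1 to compound 2 a 3.1-fold higher number from compound 1 to compound 2 (0.50 log units; beyond the scatter) is a modest rise. Compound 3 `CS(=O)(=O)c1cnc(O[C@H]2CC[C@H](OC3CCN(C(=O)C4(C(F)(F)F)CCCC4)CC3)CC2)cn1` differs from compound 1 by a group of 9 heavy atoms (6 carbon, 3 fluorine; one five-membered non-aromatic ring of carbon only) in place of a group of 5 heavy atoms (4 carbon, 1 oxygen; no ring), on a carbonyl carbon, so the change sits on the amide side rather than at the sulfonyl sulfur. Among the compounds with values here, the only measured step concerns the sulfonyl group and does not bear on this change, so the expected step of a 1.7-fold higher number from compound 1 to compound 3 (0.23 log units; within the scatter) is uncertain in direction. Compound 3 is expected near 10 nM, within 2 nM to 60 nM.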

Compound 3, half-maximal effective concentration: 38.4 nM
Compound 3: middle estimate off by 3.8-fold (0.58 log units), on the low side; the measured number falls inside the stated range.
By their numbers in this assay, from the lowest: compound 1; then compound 2; then compound 3.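

At this carbonyl carbon, in this assay, a group of 9 heavy atoms with a five-membered carbon ring and three fluorines in place of tert-butoxy gives a 6.5-fold higher number from compound 1 to compound 3 (0.81 log units; beyond the scatter). The number therefore responds to changes on this carbonyl carbon as well as at the sulfonyl sulfur. No measurement given here explains this rise.

On these data alone, the ring, the fluorines and the lost oxygen all change in one step, so their separate shares remain unknown. Also open, as far as these compounds go, is how an ethoxy group or the same carbon ring without fluorine would read here.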